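A few compounds are considered here, and "the series" means these few. Any claim that something is new, unique, unknown or untested is made for them only; others in the source may bear on it.

Measured so far:
- compound 1 `CO[C@@H]1[C@@H](OC)[C@H](c2ccccc2)O[C@@H]2CO[C@@H](c3ccccc3)O[C@@H]12`, in this test: "not determined" (no result reported)
- compound 2 `C=CC[C@@H]1O[C@@H]2CO[C@@H](c3ccccc3)O[C@H]2[C@H](OC)[C@H]1OC`, in this test: "not determined" (no result reported)
- compound 3 `O=[N+]([O-])c1ccc([C@@H]2OC[C@H]3O[C@@H](c4ccccc4)[C@H](O)[C@@H](O)[C@@H]3O2)cc1`, in this test: > 50 ug/mL

Among the compounds with values here, in a functional assay on HEL cells (Homo sapiens) for cytotoxicity (on this read-out lower numbers stand for higher toxicity in this test and higher numbers for lower toxicity in this test), compound 3 gives a limit of the assay and not a number, > 50 ug/mL, and it is the one value that sits at that limit (the limit of > 50 ug/mL in this assay, at which 1 of the 3 values shown sits). Compound 1 and compound 2 carry no result in this assay, so compound 3 is the only point of reference. Compound 4 `O[C@@H]1[C@@H](O)[C@H](c2ccccc2)O[C@@H]2CO[C@@H](c3ccc(C(F)(F)F)cc3)O[C@@H]12` differs from compound 3 by trifluoromethyl in place of nitro on an aromatic carbon. Within the data shown here, no measured step between any two compounds exists, so the size of this change cannot be read from the data. Compound 4 is expected to stay near the limit, with a step that the limit leaves unreadable from compound 3 to compound 4 that remains within the scatter. Compound 4 is thus estimated at 60 ug/mL, between 25 ug/mL and 200 ug/mL.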

Compound 4, half-maximal cytotoxic concentration: 35 ug/mL
For compound 4 the middle estimate is 1.7-fold (0.23 log units) above the measured one; measured number inside the range.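

In this assay, within the data shown here, the change from nitro to trifluoromethyl on this aromatic carbon, para to a large group, gives an at least 1.4-fold lower number from compound 3 to compound 4 (0.15 log units; that floor lies within the scatter) and so the first step at this position. Its full size cannot be read, and it does not show a change beyond the scatter. Compound 3 stands at a limit of the assay and not at a number: the limit of > 50 ug/mL in this assay, at which 1 of the 4 values shown sits. Going by these compounds, what an amine or a carboxylic acid on this aromatic carbon would give stays open, as does the outcome of this same change on another core.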